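The source may report more compounds than this note shows. Statements on the series, on what has been measured and on what is new or still open speak of the compounds shown alone.

Measured in a functional assay on WHCO1 cells (Homo sapiens) for antiproliferative activity, read by MTT assay, with a stated time of 48 h; a lower number here means a stronger inhibitor, a higher number a weaker inhibitor:
- compound 1 `C=CCSS/C=C/C[S+]([O-])CCC`: 37000 nM
- compound 2 `C=CCSS/C=C/C[S+]([O-])CCCO`: 27000 nM

Only these two numbers are available, and they do not separate compound 1 from compound 2. The step is a 1.4-fold lower number from compound 1 to compound 2 (0.14 log units; within the scatter).

Compound 3 `C=CCSS/C=C\C[S+]([O-])CCC` is the next case, set against compound 1: the two compounds have the same atoms and bonds; at least one stereo element is drawn with a configuration in one of them and without one in the other: 1 of 2 stereo elements differ; a double bond is drawn E in compound 1 and Z in compound 3.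

For the measured compounds named here, no measured step covers a change of this kind. Going by the values given here, the single step available swaps hydroxy for hydrogen on a saturated chain carbon, so it says nothing direct about double-bond geometry. It shows only that one edit to this scaffold stayed within the scatter. With nothing pointing either way, no step beyond the scatter is expected in this assay, and the estimate stays anchored on compound 1 at 37000 nM.

The expected step is a 1.2-fold lower number from compound 1 to compound 3 (0.06 log units; within the scatter).

Compound 3 is expected at 32000 nM, with an estimated range of 15000 nM to 65000 nM.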

Compound 3, half-maximal inhibitory concentration: 23000 nM
Compound 3: the middle estimate sits 1.4-fold (0.14 log units) above what was measured, within the range that was stated.
By their numbers in this assay, from the lowest: compounds 3, 2 and 1 (each within the scatter of the next).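

In this assay, the E and Z forms of this double bond are not separated, with a 1.6-fold lower number from compound 1 to compound 3 (0.21 log units; within the scatter). For the compounds shown here, the earlier pair spoke only to hydroxy in place of hydrogen on a saturated chain carbon, so this is the first reading on geometry: on the core of compound 1, the double bond can be drawn either way without a step beyond the scatter. The single difference recorded for this pair is: the fact that one of compounds 1 and 3 is drawn with a defined configuration and the other without, at the place where they differ

Going by these compounds, whether the Z double bond behaves alike when combined with the hydroxy of compound 2 remains open. Also open, on these data alone, is whether an amine, a carboxylic acid or a longer chain on the saturated chain would give a step beyond the scatter.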